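The compounds below may be only part of what the source reports. "The series", "measured", "known", "first", "only" and "open" are said of these compounds alone.

Series notes. Compound 1 `CCc1cccc(-c2nn3c(c2-c2ccnc(Cl)c2)C(C)C(C)(C)C3)n1` and compound 2 `COCC1c2c(-c3ccncc3)c(-c3cccc(C)n3)nn2CC1(C)C` share a core and have both been tested in a functional assay on MCF7 cells (Homo sapiens) for cytotoxicity, with a stated time of 72 h; a lower number here means a stronger inhibitor, a higher number a weaker inhibitor. In this assay compound 1 gives > 100000 nM, which is a limit of the assay rather than a number. In this assay compound 2 gives > 100000 nM, again a limit rather than a number. Both values shown sit at the limit of > 100000 nM in this assay, at which 2 of the 2 values shown sit, so compound 2 stands at the floor of what the measurement can report, and the numbers shown do not separate it from any other compound.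

Compound 3 `Cc1cccc(-c2nn3c(c2-c2ccncc2)C(C)C(C)(C)C3)n1` differs from compound 2 by hydrogen in place of methoxy on a saturated chain carbon bound to a saturated ring carbon. Going by the values given here, no measured step between two numbered compounds covers this change, so the size of the step from compound 2 to compound 3 in this assay cannot be read from a neighbour. With every value shown sitting at the limit of > 100000 nM in this assay, at which 2 of the 2 values shown sit, a step beyond the scatter in either direction has no support, and the step is expected to be a number no higher from compound 2 to compound 3 (the limit leaves the size open), none beyond the scatter. For compound 3 in this assay the estimate is 100000 nM, with a range from 30000 nM to 300000 nM, and the result is expected most likely to come back as a limit once more.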

Compound 3, half-maximal inhibitory concentration: > 100000 nM
Compound 3: no number, only a limit; the forecaster's own chance of this, stated with the estimate: 85%; the middle value lies on the limit itself.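

No new step can be read between compound 2 and compound 3 in this assay, since neither result is a number: the limit of > 100000 nM in this assay, at which 3 of the 3 values shown sit.

The compounds shown leave open what size the change from methoxy to hydrogen has in this assay, and whether any compound on the shared core gives a value short of the limit.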